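The source may hold more compounds than are shown below. What is called first, only, known or untested is meant among the compounds shown, and "the series" means these compounds.

Measured so far:
compound 1, `CN(C)c1ccc(C2CC(c3ccc(-n4ccnc4)cc3)=NN2C(=O)CCCl)cc1`: -2.5%
compound 2, `CN(C)c1ccc(C2CC(c3ccc(-n4ccnc4)cc3)=NN2C(=O)c2cc(Cl)cc(Cl)c2)cc1`: 58.7%

In a functional assay on NCI-H1975 cells (Homo sapiens) for inhibition, read by sulforhodamine B assay, tested at 10 uM (on this read-out lower numbers stand for less inhibition and higher numbers for more inhibition at the one concentration tested (going by the name of the read-out)), compound 2 gives 58.7%, the highest of the two numbers; the nearest is compound 1 with -2.5%. Within the data shown here, the one step measured, a number 61.2 percentage points higher from compound 1 to compound 2 (beyond the scatter), put 3,5-dichlorophenyl in place of 2-chloroethyl on the carbonyl carbon, so it exchanged a chain for a six-membered aromatic ring of carbon only.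

Compound 3, `CN(C)c1ccc(C2CC(c3ccc(-n4ccnc4)cc3)=NN2C(=O)c2ccc(C(F)(F)F)cc2)cc1`, is not yet measured. Its change from compound 2 is 4-(trifluoromethyl)phenyl in place of 3,5-dichlorophenyl on a carbonyl carbon. Among the measured compounds shown here, this keeps a six-membered aromatic ring of carbon only on the carbonyl carbon; the measured step bears on it only at a distance, since no step between two such rings has been measured. A step much smaller than the chain-to-ring step is therefore expected, likely downward but possibly within the scatter.

The estimated step is a number 13.7 percentage points lower from compound 2 to compound 3 (beyond the scatter). Compound 3 is expected to give 45% in this assay, with a range from 15% to 70%.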

Compound 3, a percentage reported as inhibition, at one concentration (the size of the read-out at that concentration, not a potency): 15.9%
For compound 3 the middle estimate is 29.1 percentage points above the measured one; low and high end bracket the measured number.
By their numbers in this assay, from the lowest: compound 1; then compound 3; then compound 2.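

In this assay, the six-membered aromatic ring on the carbonyl carbon is not enough on its own to hold the read-out: 4-(trifluoromethyl)phenyl in place of 3,5-dichlorophenyl gives a number 42.8 percentage points lower from compound 2 to compound 3 (beyond the scatter) with the ring type unchanged. Measured against the 2-chloroethyl amide, the same 4-(trifluoromethyl)phenyl group gives only a number 18.4 percentage points higher from compound 1 to compound 3 (beyond the scatter) and so keeps just part of the rise seen earlier on going from that chain to 3,5-dichlorophenyl. No measurement available explains the gap between the two aryl groups.
The two aryl groups differ in both their substituents and the ring places these occupy, so neither can be singled out as the source of the step. Groups such as 4-chlorophenyl and 3,5-bis(trifluoromethyl)phenyl on the carbonyl carbon would separate these two differences.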